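The compounds below may be only part of what the source reports. "The series", "measured", "known", "first", "only" and "open" are said of these compounds alone.

Measured so far in a toxicity assay on MT4 cells (Homo sapiens) for cytotoxicity, read by MTT assay, with a stated time of 7 days; on this read-out higher numbers stand for lower toxicity in this test and lower numbers for higher toxicity in this test:

Compound 1, `Cc1cc(C)cc(S(=O)(=O)c2c(C(=O)NC3CC4(C3)CN(S(C)(=O)=O)C4)[nH]c3ccc(Cl)cc23)c1`, gives > 233000 nM.
Compound 2, `Cc1cc(C)cc(S(=O)(=O)c2c(C(=O)NC3CC4(CCN(C(=O)OC(C)(C)C)CC4)C3)[nH]c3ccc(Cl)cc23)c1`, gives 133000 nM.
Compound 3, `Cc1cc(C)cc(S(=O)(=O)c2c(C(=O)NC3CC4(C3)CN(C(=O)OC(C)(C)C)C4)[nH]c3ccc(Cl)cc23)c1`, gives > 224000 nM.

The value for compound 1 is a limit of this assay, not a number. The value for compound 3 is likewise a limit. Among the compounds with values here, compound 2 is the one compound of the three that returns a number in this assay.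

Compound 3 and compound 1 share a core and differ in one place: methylsulfonyl in place of tert-butoxycarbonyl on an amine nitrogen in a ring. Because of the limit of > 224000 nM in this assay, at which 1 of the 3 values shown sits, and the limit of > 233000 nM in this assay, at which 1 of the 3 values shown sits, the step that the two limits leave unreadable from compound 3 to compound 1 cannot be read.

Compound 4, `Cc1cc(C)cc(S(=O)(=O)c2c(C(=O)NC3CC4(CCN(S(C)(=O)=O)CC4)C3)[nH]c3ccc(Cl)cc23)c1`, has not yet been measured. It differs from compound 2 by methylsulfonyl in place of tert-butoxycarbonyl on an amine nitrogen in a ring. The difference between the core of compound 2 and the core of compound 3 is not broken down here. The change from compound 3 to compound 1 is the same kind of change, but not the same: there the amine nitrogen sits in a four-membered non-aromatic ring with two ring bonds from the ring atom that bears two fused rings, here in a six-membered non-aromatic ring with three ring bonds from that atom.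

Compound 4 is expected to show a step of a 1.1-fold higher number from compound 2 to compound 4 (0.05 log units; within the scatter) in this assay. Compound 4 is estimated at 150000 nM, with a range from 70000 nM to 300000 nM. This rests on compound 2 at 133000 nM and on the step that the two limits leave unreadable from compound 3 to compound 1, which gives no readable size for this kind of change.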

Compound 4, half-maximal cytotoxic concentration: > 221000 nM
Compound 4: a limit, no number; the forecaster's own chance of this, stated with the estimate: 40%; middle value at least 1.4-fold (0.16 log units) away from the limit.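

In this assay, putting methylsulfonyl in place of tert-butoxycarbonyl on the amine nitrogen of the six-membered ring gives an at least 1.6-fold higher number from compound 2 to compound 4 (0.22 log units; that floor lies within the scatter), so the change comes with no sign of a lower number on this core, though the smallest step it allows does not get past the usual spread of repeat measurements. From the compounds shown here alone, compound 4 gives > 221000 nM, which is a limit of the assay and not a number, so the true size of the step stays unknown. Both ends of the same kind of change on the other core, from compound 3 to compound 1, are limits, so that step cannot be read, and nothing here shows whether the change acts alike on the two cores or differently.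

The compounds shown leave open what other groups on this ring nitrogen would give in this assay on either core, such as a free amine carrying only a hydrogen, or an acetyl group. Going by these compounds, a longer chain on the sulfonyl, such as ethylsulfonyl in place of methylsulfonyl, also remains open.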